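This account rests on a few compounds, and the source may have more. Where it says the series, first, only, none or still open, it means among the compounds named here.

Compound 1 `Cc1nc(C)c(CN2CCN(c3cccc4[nH]c(-c5ccc(C(C)(C)C)cc5)nc34)CC2)o1` gives 740 nM in an assay on isolated protein for displacement of a labelled ligand from Gonadotropin-releasing hormone receptor (Rattus norvegicus) (a higher number here means a weaker inhibitor, a lower number a stronger inhibitor), the higher of the two numbers recorded; its nearest neighbour, compound 2 `CCc1cc(CN2CCN(c3cccc4[nH]c(-c5ccc(C(C)(C)C)cc5)nc34)CC2)nn1C`, gives 350 nM. The step of a 2.1-fold lower number from compound 1 to compound 2 (0.33 log units; beyond the scatter) shows that replacing the five-membered ring at this position can lower the number modestly. Compound 3 `CCc1nc(CN2CCN(c3cccc4[nH]c(-c5ccc(C(C)(C)C)cc5)nc34)CC2)cn1C` differs from compound 1 by 2-ethyl-1-methyl-1H-imidazol-4-yl in place of 2,4-dimethyl-1,3-oxazol-5-yl on a saturated chain carbon bound to an amine nitrogen in a ring. Among the compounds with values here, only that single step bears on this change, and it was modest. A similar or smaller shift in this assay is expected, so compound 3 is estimated at 450 nM, in the range 200 nM to 1100 nM, a step of a 1.6-fold lower number from compound 1 to compound 3 (0.22 log units; within the scatter) from compound 1 that may not exceed the scatter.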

Compound 3, half-maximal inhibitory concentration: 78 nM
Compound 3: middle estimate off by 5.8-fold (0.76 log units), on the high side; the whole stated range lies above it.
By their numbers in this assay, from the lowest: compound 3; then compound 2; then compound 1.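

The choice of five-membered ring on this saturated chain carbon counts for more than the first step suggested, with a 9.5-fold lower number from compound 1 to compound 3 (0.98 log units; beyond the scatter) and, between the two ethyl- and methyl-bearing rings, a 4.5-fold lower number from compound 2 to compound 3 (0.65 log units; beyond the scatter). Ethyl and methyl groups alone therefore do not set the number, since the imidazole and pyrazole forms differ beyond the scatter. Nothing available explains this difference. Still open, going by these compounds, is whether the 2-ethyl group of compound 3 matters, and how a longer chain or a cyclopropyl group there would compare.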